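Amide nitrogen substituent swap within the methoxy series

The source may hold more compounds than are shown below. What is called first, only, known or untested is meant among the compounds shown, and "the series" means these compounds.

Going by the values given here, compound 3 `COc1ccc2c(=O)c(/C=C/C(=O)NCc3ccc(F)cc3)coc2c1` holds the only number measured so far in a functional assay on Huh-7 cells (Homo sapiens) for inhibition, read by MTT assay, with a stated time of 48 h (on this read-out lower numbers stand for stronger inhibition and higher numbers for weaker inhibition), where compound 3 gives 21000 nM. Compound 1 `O=C(/C=C/c1coc2cc(O)ccc2c1=O)NCc1ccc(F)cc1` stands at a limit of the assay, as compound 1 gives > 100000 nM in this assay. Compound 2 `Cc1ccc(CNC(=O)/C=C/c2coc3cc(O)ccc3c2=O)cc1` likewise stands at a limit, with compound 2 giving > 100000 nM in this assay. Among the compounds with values here, the only readable step is an at least 4.7-fold lower number from compound 1 to compound 3 (0.67 log units; beyond the scatter), which concerns the methyl on the oxygen that compound 3 carries and compound 4 keeps. The step that the two limits leave unreadable from compound 1 to compound 2 cannot be sized because of the limit of > 100000 nM in this assay, at which 2 of the 3 values shown sit.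

Compound 4 `COc1ccc2c(=O)c(/C=C/C(=O)Nc3ccccc3C)coc2c1` differs from compound 3 by 2-methylphenyl in place of 4-fluorobenzyl on an amide-type nitrogen. Among the measured steps only the one from compound 1 to compound 2 touches the group on the amide nitrogen, and that step gives no size. There is therefore no measured basis for expecting a shift beyond the scatter in this assay in either direction, and the expected step is a 1.2-fold higher number from compound 3 to compound 4 (0.08 log units; within the scatter). Compound 4 is accordingly estimated at 25000 nM, with a wide range from 8000 nM to 90000 nM, and a real chance that only a limit is reported.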

Compound 4, half-maximal inhibitory concentration: 26900 nM
The estimate for compound 4 lay 1.1-fold (0.03 log units) below the measured number; the range from low to high includes it.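

In this assay, going by these compounds alone, the change on the amide-type nitrogen gives a 1.3-fold higher number from compound 3 to compound 4 (0.11 log units; within the scatter), the first readable step at this position. With the methyl on the oxygen in place, 2-methylphenyl and 4-fluorobenzyl are therefore not told apart by this read-out, even though the fluorine leaves with the change and each group brings one six-membered aromatic ring of carbon only. The only step shown beyond the scatter remains the one at the oxygen, an at least 4.7-fold lower number from compound 1 to compound 3 (0.67 log units; beyond the scatter), so this pair adds no second position at which the number responds.

The step between the two compounds without that methyl cannot be read, and the amide-nitrogen groups cannot be compared in that setting, because compound 1 and compound 2 both stand at a limit: the limit of > 100000 nM in this assay, at which 2 of the 4 values shown sit.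

On these data alone, both groups compared here are uncharged and have one aromatic carbon ring, so it remains open whether a basic amine such as a piperidine, a carboxylic acid or a longer alkyl chain on the amide nitrogen would shift the number beyond the scatter.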